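Terminal aryl swap in the thiourea series: cytotoxicity outlook

The source may hold more compounds than are shown below. What is called first, only, known or untested is meant among the compounds shown, and "the series" means these compounds.

Measured compounds:
compound 1 `NC(=S)Nc1cccc(OCCCCCc2ccccc2)c1` — 22000 nM
compound 2 `CCNC(=S)Nc1cccc(OCCCCCc2ccccc2)c1` — > 50000 nM
compound 3 `S=C(NCc1ccccc1)Nc1cccc(OCCCCCc2ccccc2)c1` — 32000 nM

In an ADME assay on Ava5 cells (Homo sapiens) for cytotoxicity (on this read-out higher numbers stand for lower toxicity in this test and lower numbers for higher toxicity in this test), compound 1 gives 22000 nM. Compound 3 sits close to it, as a 1.5-fold higher number from compound 1 to compound 3 (0.16 log units; within the scatter) shows, so neither can be set apart from the other. For compound 2 the result is a limit of the assay, > 50000 nM, and the step of an at least 2.2-fold higher number from compound 1 to compound 2 (0.35 log units; beyond the scatter) is therefore known only as a floor; the limit of > 50000 nM in this assay, at which 1 of the 3 values shown sits, is the relevant boundary. The remaining step, an at least 1.5-fold lower number from compound 2 to compound 3 (0.19 log units; that floor lies within the scatter), again ends within the scatter.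

Compound 4 `NC(=S)Nc1cccc(OCCCCCOc2ccc(Br)cc2)c1` is not yet measured. It differs from compound 1 by 4-bromophenoxy in place of phenyl on a saturated chain carbon, five bonds along the chain from an oxygen on an aromatic ring. All three measured steps change the substituent on the thiourea nitrogen, whereas this change sits at the far end of the chain, so none of them bears directly on it. Within the data shown here, of the steps that are known, only the one with the ethyl reached beyond the scatter, and that with a limit. On this basis compound 4 is expected to stay close to compound 1, with the step of a 1.1-fold higher number from compound 1 to compound 4 (0.06 log units; within the scatter) estimated to lie within the scatter. The estimate for compound 4 in this assay is 25000 nM, with a range from 10000 nM to 60000 nM.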

Compound 4, half-maximal cytotoxic concentration: 19000 nM
Estimate against measurement, compound 4: 1.3-fold (0.12 log units) above, within the range that was stated.
By their numbers in this assay, from the lowest: compounds 4, 1 and 3 (each within the scatter of the next). At a limit, above all of these: compound 2.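

Working notes: the earlier steps all changed the substituent on the thiourea nitrogen, whereas this one is at the far end of the chain, and in this assay it reads as a 1.2-fold lower number from compound 1 to compound 4 (0.06 log units; within the scatter), so this read-out does not set the two compounds apart. For this single pair, 4-bromophenoxy in place of phenyl brings in an oxygen, a bromine and a hydrogen-bond acceptor at this place on the chain without a change beyond the scatter. Nothing measured here gives a cause for this result.

From the compounds shown here alone, whether this holds for other end groups stays open, for example an amine or a carboxylic acid at the chain end, or a longer chain. Also open, going by these compounds, is how 4-bromophenoxy behaves when the thiourea nitrogen carries ethyl or benzyl.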